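Adding a hydroxy-oxetane to the pyrazole side chain

The source may hold more compounds than are shown below. What is called first, only, known or untested is meant among the compounds shown, and "the series" means these compounds.

Compound 3 `Cc1nn(C)cc1Nc1nc(N)c2c(C#N)c(N3CCC[C@H]3C)n(C)c2n1` gives 120 nM in an assay on HEK293 cells for inhibition of Leucine-rich repeat serine/threonine-protein kinase 2 variant G2019S (Homo sapiens), with a stated time of 48 h (on this read-out lower numbers stand for stronger inhibition and higher numbers for weaker inhibition), the lowest of the two single numbers shown. Compound 2 `Cc1nn(CC(C)(C)O)cc1Nc1nc(N)c2c(C#N)c(N3CCC[C@H]3C)n(C)c2n1` gives 180 nM there, and compound 1 `Cc1nn(C2CCOC2)cc1Nc1nc(N)c2c(C#N)c(N3CCC[C@H]3C)n(C)c2n1` has two entries, 65 nM; 180 nM (2 entries), without one single number. The change a 1.5-fold lower number from compound 2 to compound 3 (0.18 log units; within the scatter) is within the scatter. Compound 4 `Cc1nn(CC2(O)COC2)cc1Nc1nc(N)c2c(C#N)c(N3CCC[C@H]3C)n(C)c2n1` differs from compound 3 by 3-hydroxyoxetan-3-yl in place of hydrogen on a saturated chain carbon bound to an aromatic nitrogen. Among the compounds with values here, the only measured step that bears on this, the removal of a hydroxylated group going from compound 2 to compound 3, was small, so compound 4 is expected to sit close to compound 3, with the step of a 1.5-fold higher number from compound 3 to compound 4 (0.18 log units; within the scatter) expected not to exceed the scatter. Compound 4 is therefore estimated at 180 nM in this assay, between 70 nM and 450 nM.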

Compound 4, half-maximal inhibitory concentration: 250 nM
The estimate for compound 4 lay 1.4-fold (0.14 log units) below the measured number, and the stated range covers the measured number.
By their numbers in this assay, from the lowest: compounds 3, 2 and 4 (each within the scatter of the next, the first and the last beyond it).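

In this assay, the only step shown on this saturated chain carbon bound to an aromatic nitrogen that lies beyond the scatter is the entry of 3-hydroxyoxetan-3-yl, a 2.1-fold higher number from compound 3 to compound 4 (0.32 log units; beyond the scatter), and it is modest. Exchanging one hydroxylated group for the other gives a 1.4-fold higher number from compound 2 to compound 4 (0.14 log units; within the scatter), so these two side chains cannot be told apart here. Steps of this size remain loosely fixed, as the repeat entries of another compound show: the several entries of compound 1 in this assay, 65 nM; 180 nM (2 entries)

Left open is how an amine or a carboxylic acid at this place would read, and whether a longer chain carrying the hydroxy group would differ.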